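Removing the Propyl Chain from the Piperidine Alcohol

This account rests on a few compounds, and the source may have more. Where it says the series, first, only, none or still open, it means among the compounds named here.

For the measured compounds named here, compound 3 `CCCC1(O)CCN(c2nc(C)c3cc(NC(=O)/C=C/c4ccc(Cl)cc4)ccc3n2)CC1` is one of three compounds measured in an assay on CHO-K1 cells for displacement of a labelled ligand from melanin-concentrating hormone receptor 1 (Homo sapiens), read by scintillation proximity assay, with a stated time of 2 h; a higher number here means a weaker inhibitor, a lower number a stronger inhibitor. In this assay compound 3 gives 245 nM, level with compound 1 `COCCC1(O)CCN(c2nc(C)c3cc(NC(=O)/C=C/c4ccc(Cl)cc4)ccc3n2)CC1`, for which compound 1 gives 245 nM; together these are the highest two numbers of the three. Compound 2 `Cc1nc(N2CCC(N3CCOC3=O)CC2)nc2ccc(NC(=O)/C=C/c3ccc(OC(F)(F)F)cc3)cc12`, which carries a different group on the amide side and a cyclic carbamate on the piperidine, gives 41 nM, a clearly lower number than either.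

Compound 4 `Cc1nc(N2CCC(O)CC2)nc2ccc(NC(=O)/C=C/c3ccc(Cl)cc3)cc12` differs from compound 3 in one place: hydrogen in place of propyl on a saturated ring carbon. Going by the values given here, only one measured step touches this position: no change at the digits printed from compound 1 to compound 3 (within the scatter), which exchanged one short chain for another and left the number unchanged. Among the compounds with values here, no measured step removes the chain altogether, so the effect of the bare alcohol is untested here. The closest guide suggests the chain itself contributes little, so the number for compound 4 is expected to stay near that of compound 3, with a wide range to reflect the gap in evidence. Compound 4 is therefore estimated at 300 nM, between 100 nM and 900 nM. The expected step, a 1.2-fold higher number from compound 3 to compound 4 (0.09 log units; within the scatter), lies within the scatter.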

Compound 4, half-maximal inhibitory concentration: 107 nM
Compound 4: middle estimate off by 2.8-fold (0.45 log units), on the high side; the measured number falls inside the stated range.
By their numbers in this assay, from the lowest: compound 2; then compound 4; then compounds 1 and 3 (each within the scatter of the next).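

In this assay, this ring carbon looked indifferent to what it carried, since exchanging one chain for another gave no change at the digits printed from compound 1 to compound 3 (within the scatter). Compound 4 shows that the position does respond once the chain is removed altogether: hydrogen in place of propyl gives a 2.3-fold lower number from compound 3 to compound 4 (0.36 log units; beyond the scatter), and hydrogen in place of 2-methoxyethyl gives the matching a 2.3-fold lower number from compound 1 to compound 4 (0.36 log units; beyond the scatter). So the two chains are level with each other, yet the 4-hydroxypiperidin-1-yl compound stands apart from both by a modest step, and no measurement on hand explains why this happens.

On these data alone, the three compounds give only two states of this carbon, bare or bearing a chain of the lengths in compound 1 and compound 3, so it stays open whether a single methyl would already match those chains or would stay level with compound 4. As far as these compounds go, it also remains unknown how a longer chain such as hexyl, or an amine at the end of the propyl chain, would read at this same position.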